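A Methylsulfanyl Side Chain Added to the Alanine Ester

The source may hold more compounds than are shown below. What is called first, only, known or untested is meant among the compounds shown, and "the series" means these compounds.

Measured compounds:
compound 1, `C[C@@H](O)[C@H](NC(=O)CN(c1ncnc2c1ncn2C1CCCCO1)C1CC1)C(=O)OCc1ccccc1`, 23.6%
compound 2, `O=C(CN(c1ncnc2c1ncn2C1CCCCO1)C1CC1)N[C@@H](CO)C(=O)OCc1ccccc1`, 27.8%
compound 3, `C[C@H](NC(=O)CN(c1ncnc2c1ncn2C1CCCCO1)C1CC1)C(=O)OCc1ccccc1`, 55.9%

In a functional assay on the whole organism (Tail, strain ICR) with Mus musculus as the target, in the tail flick test, with a stated time of 30 min, at a dose of 25 umol/kg by the oral route (on this read-out lower numbers stand for a weaker effect and higher numbers for a stronger effect at the one dose given), compound 3 stands highest of the three, with compound 2 nearest and compound 1 furthest. Compound 4, `CSCC[C@H](NC(=O)CN(c1ncnc2c1ncn2C1CCCCO1)C1CC1)C(=O)OCc1ccccc1`, has not yet been measured. It differs from compound 3 in one place: (methylsulfanyl)methyl in place of hydrogen on a saturated chain carbon, two bonds along the chain from an amide-type nitrogen and a carbonyl carbon.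

Among the measured compounds shown here, two measured steps bear on this change. Both end at compound 3 and both remove an oxygen-bearing group: a number 32.3 percentage points higher from compound 1 to compound 3 (beyond the scatter) and a number 28.1 percentage points higher from compound 2 to compound 3 (beyond the scatter). The second step is made at the same place as the change to compound 4, and there a hydroxy leaving raised the number. Here a (methylsulfanyl)methyl enters instead, so these steps show only that this place is sensitive, not which way a non-oxygen group will push the number. Compound 4 is therefore expected to land somewhat below compound 3, with wide uncertainty, the step being a number 13.9 percentage points lower from compound 3 to compound 4 (beyond the scatter). Compound 4 is thus estimated at 42%, between 18% and 66%.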

Compound 4, a percentage reported as activity, at one dose (the size of the read-out at that dose, not a potency): 30%
The estimate for compound 4 lay 12 percentage points above the measured number; the range from low to high includes it.
By their numbers in this assay, from the lowest: compounds 1, 2 and 4 (each within the scatter of the next); then compound 3.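

In this assay, compound 3, with only a hydrogen at this place, now stands alone above all three compounds with a longer side chain, and the new step (a number 25.9 percentage points lower from compound 3 to compound 4 (beyond the scatter)) shows that this drop does not require a hydroxy group. Putting the (methylsulfanyl)methyl in place of hydroxy (a number 2.2 percentage points higher from compound 2 to compound 4 (within the scatter)) and 2-(methylsulfanyl)ethyl in place of 1-hydroxyethyl (a number 6.4 percentage points higher from compound 1 to compound 4 (within the scatter)) both stay within the scatter, so the sulfur-bearing side chain and the two oxygen-bearing ones cannot be told apart here. Nothing measured here gives a reason for this.

With only one sulfur-bearing chain, the sulfur and the chain length cannot be separated. A plain ethyl or propyl chain would test that, while an amine or a carboxylic acid on the side chain remains an open question at this place.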